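This account rests on a few compounds, and the source may have more. Where it says the series, first, only, none or still open, it means among the compounds named here.

In a functional assay on MCF7 cells (Homo sapiens) for cytotoxicity, read by MTT assay, with a stated time of 48 h (a lower number here means a stronger inhibitor of growth, a higher number a weaker inhibitor of growth), compound 1 `Clc1cc2nc(-c3ccccc3Cl)[nH]c2cc1Cl` gives 22000 nM and compound 2 `CC(C)n1c(C(F)(F)F)nc2cc(Cl)c(Cl)cc21` gives 70500 nM. Compound 2 therefore has the higher of the two numbers and is the weaker inhibitor of growth, by a gap beyond the usual scatter. These two compounds differ in more than one place, so their gap cannot be pinned on any single change.

Compound 3 `FC(F)(F)c1nc2cc(Cl)c(Cl)cc2n1CC1CC1` has cyclopropylmethyl in place of isopropyl on an aromatic nitrogen of compound 2: cyclopropylmethyl in place of isopropyl on an aromatic nitrogen. For the measured compounds named here, no measured pair yet shows what a swap of this kind does in this assay, so the expectation stays cautious. The expected change is a 1.4-fold lower number from compound 2 to compound 3 (0.15 log units; within the scatter), leaning slightly towards a lower number but not beyond the scatter. Compound 3 is estimated at 50000 nM, with an expected range of 20000 nM to 120000 nM.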

Compound 3, concentration for 50% growth inhibition: 60200 nM
The estimate for compound 3 lay 1.2-fold (0.08 log units) below the measured number; low and high end bracket the measured number.
By their numbers in this assay, from the lowest: compound 1; then compounds 3 and 2 (each within the scatter of the next).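

For the compounds shown here, this is the first pair in which only the group on the aromatic nitrogen changes: in this assay, cyclopropylmethyl in place of isopropyl gives a 1.2-fold lower number from compound 2 to compound 3 (0.07 log units; within the scatter), so the two groups cannot be told apart by this read-out. With the trifluoromethyl group and the two chlorines held fixed, this position accepts a fourth carbon and a three-membered ring without a change beyond the usual scatter, though this single pair sets no general rule. No measurement available here explains this result.

From the compounds shown here alone, whether a longer chain, or a chain ending in an amine or a carboxylic acid, would give a number beyond the scatter at this nitrogen remains open. Also open is which of the several differences between compound 1 and compound 2 accounts for the gap between them.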